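Methyl to fluoro on the amide aryl ring

This account rests on a few compounds, and the source may have more. Where it says the series, first, only, none or still open, it means among the compounds named here.

Measured compounds:
- Compound 1, `COc1ccccc1-c1cnc(NC(=O)c2ccc(F)cc2)n1C`: > 100000 nM
- Compound 2, `COc1ccc(-c2cnc(NC(=O)c3ccccn3)n2C)cc1`: > 100000 nM
- Compound 3, `Cc1ccc(C(=O)Nc2ncc(-c3ccccc3)o2)cc1`: 26000 nM

In a toxicity assay on THP-1 cells (Homo sapiens) for inhibition (on this read-out higher numbers stand for lower toxicity in this test and lower numbers for higher toxicity in this test), compound 1 reaches only a limit, > 100000 nM, and no number. Compound 2 likewise stops at a limit in this assay, > 100000 nM. Compound 3 is the one compound of the three that gives a definite number in this assay, 26000 nM, so on the numbers shown it stands alone, with the other two values sitting at the limit of > 100000 nM in this assay, at which 2 of the 3 values shown sit. Among the measured compounds shown here, the two limits are limits and not numbers, so no step between the measured compounds can be computed. Compound 3 is the only anchor for what follows.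

Compound 4, `O=C(Nc1ncc(-c2ccccc2)o1)c1ccc(F)cc1`, is not yet measured in this assay. Its difference from compound 3 is fluoro in place of methyl on an aromatic carbon. The exchange is a single heavy atom for a single heavy atom, with no ring, donor, acceptor or charge changed.

With no measured step of this kind in the set, the expected step from compound 3 to compound 4 is small, a 1.2-fold higher number from compound 3 to compound 4 (0.06 log units; within the scatter), and may fall within the scatter. Compound 4 is therefore expected to give about 30000 nM in this assay, within a range from 10000 nM to 100000 nM.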

Compound 4, half-maximal cytotoxic concentration: 17000 nM
Beside the measured number, compound 4's estimate is 1.8-fold (0.25 log units) above it; measured number inside the range.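

Working notes on the 4-methylphenyl to 4-fluorophenyl exchange: in this assay this change gives the one step in the series that can be read, a 1.5-fold lower number from compound 3 to compound 4 (0.18 log units; within the scatter). At this position, para to a large group on a six-membered aromatic ring of carbon only, the step from methyl to fluoro therefore cannot be told apart from the scatter of this read-out, and both compounds give definite numbers rather than limits. Nothing available bears on a cause for this step.

Still open, as far as these compounds go, is whether a different group at this position, such as an amine or a carboxylic acid, would give a step beyond the scatter, and whether the exchange of methyl for fluoro would behave the same way on another core. Steps involving compound 1 and compound 2 cannot be read, as their values are limits and not numbers, so how their cores stand against that of compound 3 also remains open.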